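The compounds below may be only part of what the source reports. "The series", "measured", "known", "first", "only" and "open" are said of these compounds alone.

Series notes. The shared core of compound 1 `Cc1csc(-c2cccc(CN(C)c3ccc4[nH]nc(C(=O)O)c4c3)c2)n1` carries a 4-methyl-1,3-thiazol-2-yl group; in an assay on isolated protein for inhibition of 2-Hydroxyacid oxidase 1 (Homo sapiens), with stated times of 30 min and 15 min (a higher number here means a weaker inhibitor, a lower number a stronger inhibitor), compound 1 gives 650 nM. Compound 2 `CN(C)c1noc(-c2cccc(CN(C)c3ccc4[nH]nc(C(=O)O)c4c3)c2O)n1` gives 21 nM in this assay, so compound 1 stands highest of the two numbers shown, and its gap to compound 2 lies beyond the scatter. Compound 3 `CNCc1cccc(-c2nc(N(C)C)no2)c1O` returns only a limit of this assay, > 30000 nM; this is the limit of > 30000 nM in this assay, at which 1 of the 3 values shown sits. Compound 4 `Cc1nc(-c2cccc(CN(C)c3ccc4[nH]nc(C(=O)O)c4c3)c2)sc1C` is the open compound. Against compound 1 its change is methyl in place of hydrogen on an aromatic carbon, the 4-methyl-1,3-thiazol-2-yl group becoming 4,5-dimethyl-1,3-thiazol-2-yl, the new methyl sitting on an aromatic carbon of the five-membered ring next to the ring sulfur. Within the data shown here, no measured pair in the set carries this change, so no step on record guides it. A single added methyl of this kind is expected to move this assay little, within the scatter, in either direction. The estimated step is a 1.3-fold lower number from compound 1 to compound 4 (0.11 log units; within the scatter). Compound 4 is expected to give 500 nM in this assay, with a range from 200 nM to 1500 nM.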

Compound 4, half-maximal inhibitory concentration: 290 nM
Estimate against measurement, compound 4: 1.7-fold (0.24 log units) above, within the range that was stated.
By their numbers in this assay, from the lowest: compound 2; then compound 4; then compound 1. At a limit, above all of these: compound 3.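

The position next to the ring sulfur responds to substitution: in this assay, methyl in place of hydrogen on this aromatic carbon gives a 2.2-fold lower number from compound 1 to compound 4 (0.35 log units; beyond the scatter), a modest step. Among these compounds, this is the only step on record at this position, and it shows that a methyl here, next to the ring atom that bears a methyl group, lowers the number rather than raising it. The measurements shown offer no explanation for this step.

On these data alone, it remains open whether an ethyl group, a longer chain or an amine on this same aromatic carbon would lower the number further or reverse the step. Also open, as far as these compounds go, is how far the step depends on the methyl group already on the ring atom next to it.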